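A few compounds are considered here, and "the series" means these few. Any claim that something is new, unique, unknown or untested is made for them only; others in the source may bear on it.

Among the measured compounds shown here, compound 3 `COc1cc(-c2nnc(SCC(=O)c3ccc(C)cc3)n2N2C(=O)c3ccccc3C2=O)cc(OC)c1OC` is the one member of this small set that gives a number rather than a limit in a functional assay on MKN-45 cells (Homo sapiens) for cytotoxicity, read by MTT assay, with a stated time of 48 h; a lower number here means a stronger inhibitor, a higher number a weaker inhibitor: compound 3 gives 9620 nM. Compound 1 `C=CCSc1nnc(-c2cc(OC)c(OC)c(OC)c2)n1N1C(=O)c2ccccc2C1=O` reaches only the limit of this assay, > 200000 nM. Compound 2 `COc1cc(-c2nnc(SCc3ccccc3Cl)n2N2C(=O)c3ccccc3C2=O)cc(OC)c1OC` likewise reaches only the limit, > 200000 nM. Measured against (the limit of > 200000 nM in this assay, at which 2 of the 3 values shown sit), the steps to compound 3 are large: an at least 20-fold lower number from compound 1 to compound 3 (1.31 log units; beyond the scatter) and an at least 20-fold lower number from compound 2 to compound 3 (1.31 log units; beyond the scatter). The step between compound 1 and compound 2 is itself unreadable, a step that the two limits leave unreadable from compound 1 to compound 2.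

Compound 4 `COc1cc(-c2nnc(SCc3ccccc3)n2N2C(=O)c3ccccc3C2=O)cc(OC)c1OC` differs from compound 3 by phenyl in place of (4-methylphenyl)carbonyl on a saturated chain carbon bound to a sulfur. Seen one bond further out, this is ((4-methylphenyl)carbonyl)methyl giving way to benzyl, so compound 4 carries a benzylsulfanyl group much like the one in compound 2, without the chlorine. For the measured compounds named here, both steps that bear on the change point the same way: the carbonyl-bearing group was present in the only compound with a number and absent in the two that sit at the limit, as an at least 20-fold lower number from compound 2 to compound 3 (1.31 log units; beyond the scatter) and an at least 20-fold lower number from compound 1 to compound 3 (1.31 log units; beyond the scatter) show. The step from compound 3 to compound 4 is therefore expected to run upward and to be large, a 16-fold higher number from compound 3 to compound 4 (1.19 log units; beyond the scatter). Compound 4 is estimated at 150000 nM, within a range from 30000 nM to 400000 nM, with a fair chance that this assay reports only its limit.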

Compound 4, half-maximal inhibitory concentration: > 200000 nM
Compound 4: a limit, no number; the forecaster's own chance of this, stated with the estimate: 55%; at least 1.3-fold (0.12 log units) between middle value and limit.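

The new compound shows that the number seen for compound 3 does not hold when the group on the saturated chain carbon bound to a sulfur is changed to a plain phenyl: in this assay the result is an at least 20-fold higher number from compound 3 to compound 4 (1.31 log units; beyond the scatter). Compound 2 had left open whether its chloro group went with its limit, but compound 4, with hydrogen in place of chloro on an aromatic carbon, also gives only a limit, so the limit is not confined to the chlorinated compound; the steps from compound 1 and compound 2 to compound 4 join two limits and cannot be read. Compound 3 is now the only compound with a number, and the others stand together: the limit of > 200000 nM in this assay, at which 3 of the 4 values shown sit.

Compound 3 and compound 4 differ by the whole (4-methylphenyl)carbonyl group, so the carbonyl and the methyl on the ring leave together, and the compounds shown do not separate them. A benzoyl group without that methyl, or a carboxylic acid or an amide on the same chain carbon, would tell whether the carbonyl is enough to give a number.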